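The compounds below may be only part of what the source reports. "The series", "measured", "known", "first", "only" and "open" are said of these compounds alone.

Measured compounds:
- compound 1, `COc1cccc(C(=O)Nc2cc(-c3ccccc3)nn2-c2ccccc2)c1`: in an assay on HEK293 cells for displacement of a labelled ligand from metabotropic glutamate receptor 5 (Rattus norvegicus) (a higher number here means a weaker inhibitor, a lower number a stronger inhibitor), compound 1 gives 1290 nM
- compound 2, `O=C(Nc1cc(-c2ccccc2)nn1-c1ccccc1)c1cccc([N+](=O)[O-])c1`: in this assay compound 2 gives 2220 nM
- compound 3, `O=C(Nc1cc(-c2ccccc2)nn1-c1ccccc1)c1ccc(OC(F)(F)F)cc1`: in this assay compound 3 gives 265 nM

All three share the same core and differ only in the substituent on the ring of the amide part. Compound 3 holds the lowest number of the three, and its gaps to compound 1 and to compound 2 both lie beyond the scatter. Among the measured compounds shown here, the only single-point step among the measured compounds is a 1.7-fold higher number from compound 1 to compound 2 (0.24 log units; within the scatter), which concerns a different substituent at a different place on that ring and does not touch the trifluoromethoxy group of compound 3.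

Compound 4 is `O=C(Nc1cc(-c2ccccc2)nn1-c1ccccc1)c1ccc(C(F)(F)F)cc1`. Its difference from compound 3 is trifluoromethyl in place of trifluoromethoxy on an aromatic carbon. For the measured compounds named here, no measured step involves the removal of the oxygen of a trifluoromethoxy group, so there is nothing that shows how large such a step is, in either direction. With no evidence of a shift, the step from compound 3 to compound 4 in this assay is expected to be a 1.1-fold higher number from compound 3 to compound 4 (0.05 log units; within the scatter), that is, no change beyond the scatter. On that basis compound 4 is estimated to give 300 nM in this assay, with a range from 110 nM to 850 nM.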

Compound 4, inhibition constant: 990 nM
For compound 4 the middle estimate is 3.3-fold (0.52 log units) below the measured one; measured number outside the range, above it.
By their numbers in this assay, from the lowest: compound 3; then compounds 4, 1 and 2 (each within the scatter of the next, the first and the last beyond it).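

In this assay the low number of compound 3 proves not to carry over to trifluoromethyl at this place on the ring, para to a large group: the loss of the oxygen alone gives a clear step (a 3.7-fold higher number from compound 3 to compound 4 (0.57 log units; beyond the scatter)). Among the compounds shown here, the change therefore separates two fluorinated groups that the earlier compounds could not compare, and the trifluoromethyl compound no longer stands apart from the 3-methoxyphenyl compound (a 1.3-fold lower number from compound 1 to compound 4 (0.11 log units; within the scatter)), although it keeps a modest gap to the 3-nitrophenyl compound (a 2.2-fold lower number from compound 2 to compound 4 (0.35 log units; beyond the scatter)). No measurement shown here offers an explanation for the step from trifluoromethoxy to trifluoromethyl.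

Open, going by these compounds, is whether other groups at the same place, such as an ethoxy group, a dimethylamino group or a carboxylic acid, would follow trifluoromethoxy or trifluoromethyl. Also open, on these data alone, is whether the gap between trifluoromethoxy and trifluoromethyl holds at the other places on this ring or with a different group on the shared core.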